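Ethyl to Isopropyl: a Small Step Expected

The source may hold more compounds than are shown below. What is called first, only, known or untested is meant among the compounds shown, and "the series" means these compounds.

Measured so far in a functional assay on PC-3 cells (Homo sapiens) for inhibition, read by MTT assay, with a stated time of 48 h; on this read-out higher numbers stand for weaker inhibition and lower numbers for stronger inhibition:
- compound 1, `CCn1c(/C=C2\SC(=O)N(CC(=O)N3CCc4cc(OC)c(OC)cc4C3)C2=O)nc2ccccc21`: 33500 nM
- compound 2, `CCn1c(/C=C2\SC(=O)N(CC(=O)N3CC(C)OC(C)C3)C2=O)nc2ccccc21`: > 50000 nM

Among the measured compounds shown here, compound 1 is the only compound with a numerical result in this assay, where compound 1 gives 33500 nM. For compound 2 the value of > 50000 nM is a limit of the assay rather than a number. For the measured compounds named here, the two results therefore tell only that compound 1 was measurable while compound 2 was not; (the limit of > 50000 nM in this assay, at which 1 of the 2 values shown sits).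

Compound 3, `COc1cc2c(cc1OC)CN(C(=O)CN1C(=O)S/C(=C\c3nc4ccccc4n3C(C)C)C1=O)CC2`, has not yet been measured. It differs from compound 1 by methyl in place of hydrogen on a saturated chain carbon bound to an aromatic nitrogen and a saturated chain carbon. Going by the values given here, with no measured step of this kind, the expected step from compound 1 to compound 3 is a 1.0-fold lower number from compound 1 to compound 3 (0.02 log units; within the scatter), no larger than the scatter of repeated measurements, in either direction. Compound 3 is thus estimated at 32000 nM, within 12000 nM to 80000 nM.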

Compound 3, half-maximal inhibitory concentration: > 50000 nM
Compound 3: no number, only a limit; the forecaster's own chance of this, stated with the estimate: 30%; middle value at least 1.5-fold (0.19 log units) from the limit.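

Among the compounds shown here, this is the first measured change at this place on the core of compound 1: going from 1-ethyl-1H-benzimidazol-2-yl to 1-isopropyl-1H-benzimidazol-2-yl, with the rest of the molecule kept, gives an at least 1.4-fold higher number from compound 1 to compound 3 (0.17 log units; that floor lies within the scatter). The result for compound 3 in this assay is a limit of the assay and not a number, so it shows no gain in strength from the added methyl, but it leaves the true size of the step unknown. The reading stops at the edge of what the assay reports: the limit of > 50000 nM in this assay, at which 2 of the 3 values shown sit.

Still open, going by these compounds, is whether a plain methyl at this place, in place of the ethyl, would give a lower number than compound 1 does. On these data alone, it is equally open how a longer chain such as n-butyl, or a benzyl group, would read in this assay.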